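The source may hold more compounds than are shown below. What is called first, only, known or untested is meant among the compounds shown, and "the series" means these compounds.

Working notes on the series.

Three compounds have been run so far in a functional assay on PC-3 cells (Homo sapiens) for inhibition, read by MTT assay, with a stated time of 72 h; a lower number here means a stronger inhibitor, a higher number a weaker inhibitor. Compound 1 `O=C(CSc1nc(Nc2ccccc2)c2ccccc2n1)Nc1ccc(Br)cc1` gives 8450 nM in this assay. Compound 2 `O=C(CSc1nc(Nc2ccccc2)c2ccccc2n1)Nc1ccc(C(F)(F)F)cc1` gives 10400 nM in this assay. For the measured compounds named here, the single change between them, (trifluoromethyl in place of bromo on an aromatic carbon), produced a 1.2-fold higher number from compound 1 to compound 2 (0.09 log units; within the scatter), so the two compounds cannot be told apart on this read-out. Compound 3 `C=CC(=O)Nc1cccc(NC(=O)CSc2nc(Nc3ccc(Br)cc3)c3ccccc3n2)c1` gives 12400 nM in this assay; this number sits within the scatter of both compound 1 and compound 2, so no order among the three can be drawn. The difference between the core of compound 1 and the core of compound 3 is not broken down here.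

Going by the values given here, compound 4 `C=CC(=O)Nc1cccc(NC(=O)CSc2nc(Nc3ccc(C(F)(F)F)cc3)c3ccccc3n2)c1` is the one compound of the set without a number. It differs from compound 3 by trifluoromethyl in place of bromo on an aromatic carbon. This is the same change, at the same kind of place, that was made from compound 1 to compound 2, where the outcome was a 1.2-fold higher number from compound 1 to compound 2 (0.09 log units; within the scatter). Nothing else in the set speaks to this change, so the expectation rests on that one step alone. The step from compound 3 to compound 4 is estimated to be a 1.2-fold higher number from compound 3 to compound 4 (0.08 log units; within the scatter), a small one that would stay within the usual scatter. Compound 4 is therefore expected to give about 15000 nM in this assay, with a likely range from 6000 nM to 40000 nM. Whether the weak end of this range is still reported as a number rather than a limit remains to be seen.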

Compound 4, half-maximal inhibitory concentration: 12500 nM
Compound 4: middle estimate off by 1.2-fold (0.08 log units), on the high side; the range from low to high includes it.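

In this assay, trifluoromethyl in place of bromo gives a 1.0-fold higher number from compound 3 to compound 4 (0.00 log units; within the scatter), so on this second core the change again leaves the read-out where it was. Set beside the earlier step, the result carries over from one core to the other without a detectable difference: the same change on two cores in this assay, a 1.2-fold higher number (0.09 log units; within the scatter) from compound 1 to compound 2 and a 1.0-fold higher number (0.00 log units; within the scatter) from compound 3 to compound 4, 1.2-fold (0.09 log units) apart, within the scatter of two such steps. This shows only that, on these two cores and at numbers of this size, the exchange of these two groups is silent on this read-out; it does not show that the same would hold on a further core, and with both steps inside the scatter, two pairs cannot reveal a small real effect of the change or support a general rule for the series.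

The compounds shown leave open whether a different group in that place, such as an amine, a carboxylic acid or a methoxy group, would move the number beyond the scatter on either core. Also open, as far as these compounds go, is how the difference between the core of compound 1 and the core of compound 3 breaks down into single changes, and whether any one of those changes matters on its own.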